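This account rests on a few compounds, and the source may have more. Where it says the series, first, only, none or still open, it means among the compounds named here.

Series in a functional assay on SW480 cells (Homo sapiens) for antiproliferative activity, read by MTT assay, with a stated time of 48 h; on this read-out lower numbers stand for stronger inhibition and higher numbers for weaker inhibition:
- compound 1 `CCCCCC(CCO)n1cnc2c(Cl)nc(F)nc21`: 7440 nM
- compound 2 `CCCCCC(CCO)n1cnc2c(Cl)nc(Cl)nc21`: 6010 nM
- compound 3 `CCCCCC(CCO)n1cnc2c(N)nc(Cl)nc21`: > 50000 nM (a limit of the assay, not a number)
- compound 4 `CCCCCCCCCC(CCO)n1cnc2c(Cl)nc(Cl)nc21`: not yet measured

Only compound 1 and compound 2 have actual numbers in this assay, and they cannot be told apart: a 1.2-fold lower number from compound 1 to compound 2 (0.09 log units; within the scatter). Compound 2 therefore stands level with compound 1, at the active end of this short series. The value of compound 3 is a limit.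

The step under consideration is butyl in place of hydrogen on a saturated chain carbon, six bonds along the chain from an aromatic nitrogen. The chain grows, while the core of compound 2 stays unchanged.

Neither measured step touches the chain, so the series holds no direct evidence on this change. Both measured steps are exchanges on an aromatic carbon: a 1.2-fold lower number from compound 1 to compound 2 (0.09 log units; within the scatter) for the halogen swap and an at least 8.3-fold higher number from compound 2 to compound 3 (0.92 log units; beyond the scatter) for amino in place of chloro. Compound 4 keeps both chloro groups of compound 2, so the loss seen with compound 3 is not expected to carry over. No change beyond the scatter is expected in this assay, with only a slight lean towards a lower number and a wide margin on either side.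

The expected step is a 1.5-fold lower number from compound 2 to compound 4 (0.18 log units; within the scatter).

For compound 4 the estimated value is 4000 nM, with an expected range of 1200 nM to 15000 nM.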

Compound 4, half-maximal inhibitory concentration: 36300 nM
Beside the measured number, compound 4's estimate is 9.1-fold (0.96 log units) below it; the whole stated range lies below it.
By their numbers in this assay, from the lowest: compounds 2 and 1 (each within the scatter of the next); then compound 4. At a limit, above all of these: compound 3.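

Working notes on the chain: in this assay this position is not neutral, since butyl in place of hydrogen gives a 6.0-fold higher number from compound 2 to compound 4 (0.78 log units; beyond the scatter) while the core stays as it was. For the compounds shown here, this is the first measured change away from the aromatic carbons, and it shows that chain growth, on a saturated chain carbon, six bonds along the chain from an aromatic nitrogen, weakens inhibition without any exchange on the core. The step is modest and compound 4 still returns a number, whereas compound 3 alone stands at a limit of the assay: the limit of > 50000 nM in this assay, at which 1 of the 4 values shown sits.

With only hydrogen and butyl compared at this place, the compounds shown leave open whether the loss grows steadily along the chain or sets in at a particular length, and whether an ethyl group or a longer chain would follow the same course. Also open, as far as these compounds go, are whether a terminal amine or carboxylic acid on the chain, or a phenyl ring in place of butyl, would hold the number nearer that of compound 2, and whether the longer chain and the amino exchange combine when present together.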